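Compound 4 Against the Three Measured Entries

The source may report more compounds than this note shows. Statements on the series, on what has been measured and on what is new or still open speak of the compounds shown alone.

Compound 1, `NNC(=O)COc1ccncc1-c1ccc2ccccc2c1`: "not determined" (no result reported)
Compound 2, `O=C(/C=C/c1ccncc1-c1ccc2ncccc2c1)N1CCOCC1`: "not determined" (no result reported)
Compound 3, `CCOC(=O)/C=C/c1ccncc1-c1ccc2[nH]ccc2c1`: 4830 nM

In a functional assay on HCT-116 cells (Homo sapiens) for inhibition, read by MTT assay, with a stated time of 72 h (a higher number here means a weaker inhibitor of growth, a lower number a stronger inhibitor of growth), compound 1 has no single number, and compound 2 likewise gives none. Only compound 3 carries a result, 4830 nM, so compound 1 stands unplaced among the numbers shown, with one further entry also without a value. Compound 4, `NC(=O)/C=C/c1ccncc1-c1ccc2ccccc2c1`, is the next entry for this assay and differs from compound 1 in one place: 2-carbamoylethenyl in place of (aminocarbamoyl)methoxy on an aromatic carbon. Among the compounds with values here, no step between measured compounds is known, so no direction can be read from the data; with compound 3 as the only anchor, compound 4 is expected to land near it, and its value in this assay is estimated at 4000 nM, within 800 nM to 20000 nM.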

Compound 4, concentration for 50% growth inhibition: 12100 nM
The estimate for compound 4 lay 3.0-fold (0.48 log units) below the measured number; low and high end bracket the measured number.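

In this assay compound 4 yields no readable step from compound 1, which has no single number there. The compounds shown leave open how 2-carbamoylethenyl compares with (aminocarbamoyl)methoxy on the shared core. No evidence on hand bears on this result.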